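Removing the phenyl from compound 2 in the bicyclic amine series

The compounds below may be only part of what the source reports. "The series", "measured", "known", "first", "only" and "open" are said of these compounds alone.

Compound 1 `Brc1cncc(N2C[C@H]3CNC[C@H]3C2)c1` is the most potent member measured so far: in an assay on membranes from brain for displacement of a labelled ligand from Neuronal acetylcholine receptor; alpha4/beta2 (Rattus norvegicus) (a lower number here means a stronger inhibitor, a higher number a weaker inhibitor), compound 1 gives 0.06 nM. Compound 2 `c1ccc(-c2ccc(N3C[C@H]4CNC[C@H]4C3)nc2)cc1` carries a phenyl on the aromatic carbon of its core. In this assay compound 2 gives > 100000 nM, which is a limit of the assay and not a number, so compound 2 stands only at the weak end of the measured range (the limit of > 100000 nM in this assay, at which 1 of the 2 values shown sits). Compound 3 `c1ccc(N2C[C@H]3CNC[C@H]3C2)nc1` differs from compound 2 in one place: hydrogen in place of phenyl on an aromatic carbon. Going by the values given here, no measured step covers this change. The expectation is that the step from compound 2 to compound 3 is a large gain, with an at least 5000-fold lower number from compound 2 to compound 3 (3.69 log units; beyond the scatter) well beyond the scatter, since the much smaller compound 1 sits at 0.06 nM. Compound 3 is therefore expected to give about 20 nM in this assay, within 1 nM to 500 nM.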

Compound 3, inhibition constant: 260 nM
Compound 3: middle estimate off by 13-fold (1.11 log units), on the low side, and the stated range covers the measured number.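

Hydrogen in place of phenyl on this aromatic carbon, two atoms from the ring nitrogen and para to a group of 8 heavy atoms, gives the first step read at this position in this assay, with an at least 380-fold lower number from compound 2 to compound 3 (2.58 log units; beyond the scatter) on that single change. In this pair, then, phenyl at this position goes with the loss of a readable value, and hydrogen restores one. Compound 2 stands at a limit of the assay and not at a number, and because of this the step gives only a minimum size: the limit of > 100000 nM in this assay, at which 1 of the 3 values shown sits.

On these data alone, whether a methyl, a chlorine or a methoxy group on this carbon would behave like hydrogen or like phenyl stays open. Also open, as far as these compounds go, is whether a phenyl would cost as much on the core of compound 1.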